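Working notes: amine change from compound 3 to compound 4

This account rests on a few compounds, and the source may have more. Where it says the series, first, only, none or still open, it means among the compounds named here.

Measured so far:
- compound 1 `CN(CC#CCCC1SCCCS1)Cc1cccc2ccccc12` gives > 10000000 nM (a limit)
- compound 2 `CCN(CC)CC#CCCC1(C(O)(c2ccccc2)C2CCCC2)SCCCS1` gives 980 nM
- compound 3 `CN(CC#CCCC1(C(O)(c2ccccc2)c2ccccc2)SCCCS1)CCCc1ccccc1` gives 1630 nM

All three readings come from a functional assay for antagonist activity, with Cavia porcellus as the target (on this read-out higher numbers stand for weaker inhibition and lower numbers for stronger inhibition), and are the only data in hand for the series. The entry for compound 1 is a limit of the assay and not a number. Compound 3 lies within the usual scatter of compound 2, so the two numeric values cannot be put in order.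

The next compound is compound 4 `OC(c1ccccc1)(c1ccccc1)C1(CCC#CCN2CCCCC2)SCCCS1`, not yet measured. It carries piperidin-1-yl in place of methyl(3-phenylpropyl)amino on a saturated chain carbon bound to a triple-bonded carbon.

Among the measured compounds shown here, no measured step isolates this change, so the expectation rests on little. Compound 2 at 980 nM and compound 3 at 1630 nM sit close together, which gives no ground for expecting a large move. A modest shift towards a lower number in this assay is expected, only a little beyond the scatter, with a wide margin either way. The expected change is a 2.3-fold lower number from compound 3 to compound 4 (0.37 log units; beyond the scatter) on this estimate. The estimated value for compound 4 is 700 nM (expected range 150 nM to 3500 nM).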

Compound 4, antagonist equilibrium constant: 1000 nM
Beside the measured number, compound 4's estimate is 1.4-fold (0.15 log units) below it; measured number inside the range.
By their numbers in this assay, from the lowest: compounds 2, 4 and 3 (each within the scatter of the next). At a limit, above all of these: compound 1.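

Among the compounds shown here, the exchange of methyl(3-phenylpropyl)amino for piperidin-1-yl on a saturated chain carbon bound to a triple-bonded carbon gives the first step in this assay that isolates a single change, a 1.6-fold lower number from compound 3 to compound 4 (0.21 log units; within the scatter), so this read-out does not separate the two amines. The group leaving carries 11 heavy atoms and a six-membered aromatic ring of carbon only, whereas the group entering carries 6 heavy atoms and a six-membered non-aromatic ring, and this difference in the amine leaves compound 4 within the scatter of compound 3. Nothing in the data on hand accounts for this step.

Going by these compounds, whether another amine at this place, such as pyrrolidin-1-yl, morpholin-4-yl or dimethylamino, or a longer chain carrying the amine, would give a step beyond the scatter remains open. For the compounds shown here, the entry for compound 1, > 10000000 nM, is a limit of the assay and not a number, and no step to it can be read.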